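Thiophene-to-furan swap on two related pyridine cores

A few compounds are considered here, and "the series" means these few. Any claim that something is new, unique, unknown or untested is made for them only; others in the source may bear on it.

Measured so far:
- compound 1, `Oc1cccc(-c2cc(-c3ccccc3)cc(-c3ccsc3)n2)c1`: 75.8%
- compound 2, `Oc1cccc(-c2cc(-c3ccccc3)cc(-c3ccco3)n2)c1`: 10.2%
- compound 3, `Oc1cccc(-c2cc(-c3ccccc3)nc(-c3ccsc3)c2)c1`: 6.9%

In an assay on isolated protein for inhibition of DNA topoisomerase 1 (Homo sapiens), with a stated time of 30 min, tested at 100 uM (a higher number here means a stronger effect of the compound at the concentration tested, a lower number a weaker effect), compound 1 gives 75.8%, and compound 2 gives 10.2%. The change between them is furan-2-yl in place of thiophen-3-yl on an aromatic carbon. Within the data shown here, this gives a number 65.6 percentage points lower from compound 1 to compound 2 (beyond the scatter), which is beyond the scatter and the one clear step within the set.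

Compound 3 carries the same atoms as compound 1 joined differently; the difference between the two cores is not broken down here. In this assay compound 3 gives 6.9%, which stands lowest of the three numbers, though its gap to compound 2 is within the scatter.

Compound 4, `Oc1cccc(-c2cc(-c3ccccc3)nc(-c3ccco3)c2)c1`, is not yet measured. It differs from compound 3 by furan-2-yl in place of thiophen-3-yl on an aromatic carbon, the same change that was made from compound 1 to compound 2. On the core of compound 1 that change removed most of the inhibition. On the core of compound 3 there is little left to remove, because compound 3 already gives only 6.9% in this assay. The step is therefore expected to be small, estimated as a number 1.9 percentage points lower from compound 3 to compound 4 (within the scatter), beside the large one from compound 1 to compound 2. Compound 4 is expected to give about 5%, within an estimated range from -5% to 20%.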

Compound 4, a percentage reported as inhibition, at one concentration (the size of the read-out at that concentration, not a potency): 48.8%
Estimate against measurement, compound 4: 43.8 percentage points below, outside the stated range (above it).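

On the core of compound 3, furan-2-yl in place of thiophen-3-yl gives a number 41.9 percentage points higher from compound 3 to compound 4 (beyond the scatter), whereas the same change on the core of compound 1 gives a number 65.6 percentage points lower from compound 1 to compound 2 (beyond the scatter). The effect of this change therefore does not carry from one core to the other in this assay, where even its direction reverses: the same change on two cores in this assay, a number 65.6 percentage points lower (beyond the scatter) from compound 1 to compound 2 and a number 41.9 percentage points higher (beyond the scatter) from compound 3 to compound 4, 107.5 percentage points apart, beyond the scatter of two such steps

This rests on a single pair per core, and the read-outs are sizes of effect at one concentration rather than potencies, so the result gives no cause for the reversal and no general rule for either core, nor does it rank the two groups beyond these four compounds.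

Still open, going by these compounds, is whether the reversal follows the exchange of sulfur for oxygen or the shift in ring attachment from the 3-yl to the 2-yl form, two features that change together here and that thiophen-2-yl and furan-3-yl on each core would separate. Also open, on these data alone, is whether the reversal extends to groups of another kind at the same place, such as an amine or a carboxylic acid.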